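The compounds below may be only part of what the source reports. "The series", "measured", "known", "first", "only" and "open" are said of these compounds alone.

Working notes on the series. Compound 3 `COc1ccc(C(=O)/C=C/c2cc(-c3cc(OC)c(OC)c(OC)c3)n[nH]2)cc1OC` is the reference point for the next step. In a functional assay on RPMI-8226 cells (Homo sapiens) for cytotoxicity, read by sulforhodamine B assay, with a stated time of 48 h, tested at 0.01 uM (a lower number here means a stronger effect, a higher number a weaker effect of the compound at the concentration tested), compound 3 gives 94%. That number lies within the usual scatter of compound 1 `COc1cc(-c2cc(/C=C/C(=O)c3ccc(N)cc3)[nH]n2)cc(OC)c1OC` at 98% and of compound 2 `COc1cc(-c2cc(/C=C/C(=O)c3ccc(Cl)c(Cl)c3)[nH]n2)cc(OC)c1OC` at 100%, so the three measured compounds are not separated from one another. All recorded steps exchange the aryl group on the carbonyl carbon: a number 2 percentage points higher from compound 1 to compound 2 (within the scatter), a number 4 percentage points lower from compound 1 to compound 3 (within the scatter) and a number 6 percentage points lower from compound 2 to compound 3 (within the scatter), each of them within the scatter. Compound 4 `COc1ccc(C(=O)/C=C/c2cc(-c3cc(OC)c(OC)c(OC)c3)n[nH]2)cc1` differs from compound 3 in hydrogen in place of methoxy on an aromatic carbon. Among the compounds with values here, no measured step touches this part of the structure, so the measured steps bear on it only indirectly: three different aryl groups left the read-out unchanged within the scatter. On that basis no step beyond the scatter is expected for the move a number 1 percentage points higher from compound 3 to compound 4 (within the scatter). Compound 4 is accordingly estimated at 95%, with an expected range from 85% to 102%.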

Compound 4, a percentage reported as activity, at one concentration (the size of the read-out at that concentration, not a potency): 98%
The estimate for compound 4 lay 3 percentage points below the measured number; the measured number falls inside the stated range.
By their numbers in this assay, from the lowest: compounds 3, 1, 4 and 2 (each within the scatter of the next).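

Within the data shown here, removing one methoxy from the aryl group on the carbonyl carbon gives the first measured change at this place: in this assay, a number 4 percentage points higher from compound 3 to compound 4 (within the scatter), so going from 3,4-dimethoxyphenyl to 4-methoxyphenyl does not separate the two compounds. The 4-methoxyphenyl compound is not separated from the other aryl groups either, with a number 2 percentage points lower from compound 2 to compound 4 (within the scatter) and no change at the digits printed from compound 1 to compound 4 (within the scatter), the last being methoxy in place of amino on an aromatic carbon. The data give no explanation for this flat read-out.

As far as these compounds go, whether a hydroxy group, a carboxylic acid or a longer chain such as butoxy in place of the methoxy would move the read-out beyond the scatter stays open. From the compounds shown here alone, the read-out was taken at one concentration only, so whether these four compounds would show a stronger or weaker effect relative to one another at any other concentration remains open.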